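Series notes: octylphenyl amides, amino-hydroxy side chain variation

A few compounds are considered here, and "the series" means these few. Any claim that something is new, unique, unknown or untested is made for them only; others in the source may bear on it.

Compound 2 `CCCCCCCCc1ccc(NC(=O)C(N)C(C)(C)O)cc1` is the higher of the two numbers shown in an assay on isolated protein for inhibition of sphingosine kinase 1 (Homo sapiens), read by mobility shift assay (on this read-out lower numbers stand for stronger inhibition and higher numbers for weaker inhibition), where compound 2 gives 2100 nM. Compound 3 `CCCCCCCCc1ccc(NC(=O)[C@@H](N)[C@@H](C)O)cc1` gives 650 nM in this assay. Compound 1 `CCCCCCCCc1ccc(NC(=O)C(C)(N)CO)cc1` sits at a limit of this assay, > 10000 nM, so no number is known for it (the limit of > 10000 nM in this assay, at which 1 of the 3 values shown sits).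

Compound 4 `CCCCCCCCc1ccc(NC(=O)[C@H](N)[C@@H](C)O)cc1` is not yet measured. Against compound 2 the change is 1-amino-2-hydroxypropyl in place of 1-amino-2-hydroxy-2-methylpropyl on a carbonyl carbon; the entering group is the one carried by compound 3, in a different configuration at its stereocentres.

The step that bears most directly on this is a 3.2-fold lower number from compound 2 to compound 3 (0.51 log units; beyond the scatter), the same replacement with the configuration of compound 3. The steps of an at least 4.7-fold lower number from compound 1 to compound 2 (0.67 log units; beyond the scatter) and an at least 15-fold lower number from compound 1 to compound 3 (1.18 log units; beyond the scatter) start from a limit and place compound 3 below compound 2 in this assay. Since compound 4 carries the entering group in the other configuration, the gain seen for compound 3 is not assumed in full; a step from compound 2 to compound 4 in this assay that stays within the scatter, or is at most modest toward a lower number, is expected, a 1.4-fold lower number from compound 2 to compound 4 (0.15 log units; within the scatter).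

Compound 4 is therefore estimated at 1500 nM in this assay, with a range from 500 nM to 5000 nM.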

Compound 4, half-maximal inhibitory concentration: 1600 nM
Estimate against measurement, compound 4: 1.1-fold (0.03 log units) below, and the stated range covers the measured number.
By their numbers in this assay, from the lowest: compound 3; then compounds 4 and 2 (each within the scatter of the next). At a limit, above all of these: compound 1.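

In this assay, the pair with the same atoms and bonds gives a 2.5-fold higher number from compound 3 to compound 4 (0.39 log units; beyond the scatter), which makes the drawn configuration at one stereocentre at a saturated chain carbon enough to move the number beyond the scatter: the fact that compounds 3 and 4 differ only in the configuration as drawn. The same group replacement on the carbonyl carbon, 1-amino-2-hydroxypropyl in place of 1-amino-2-hydroxy-2-methylpropyl, gives a 1.3-fold lower number from compound 2 to compound 4 (0.12 log units; within the scatter) in this configuration, against a 3.2-fold lower number from compound 2 to compound 3 (0.51 log units; beyond the scatter) in the configuration of compound 3, so the entering group does not bring a step beyond the scatter independent of its configuration. The step of an at least 6.2-fold lower number from compound 1 to compound 4 (0.79 log units; beyond the scatter) starts from compound 1, whose value is a limit and not a number, so it sets only a bound: the limit of > 10000 nM in this assay, at which 1 of the 4 values shown sits.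

The effect of inverting the second stereocentre of the 1-amino-2-hydroxypropyl group stays open, as does the size of any step from the two configurations shown to the remaining stereoisomers. Also open, going by these compounds, is whether the configuration step at this position holds with a methoxy group in place of the hydroxyl or with a decyl chain in place of the octyl chain.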